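A smaller side chain on the shared core

The compounds below may be only part of what the source reports. "The series", "measured", "known", "first", "only" and "open" are said of these compounds alone.

Compound 1 `O=S(=O)(c1ccc([C@H]2CC[C@]3(CC2)OOC2(O3)C3CC4CC(C3)CC2C4)cc1)N1CCNCC1` gives 16 mL.min-1.g-1 in an ADME assay on microsomes from liver (Homo sapiens) for metabolic stability, read by LC-MS, tested at 1 uM (on this read-out lower numbers stand for slow clearance and higher numbers for fast clearance), and compound 2 `CC(C)(O)CNCCCOc1ccc([C@H]2CC[C@]3(CC2)OOC2(O3)C3CC4CC(C3)CC2C4)cc1` gives 8 mL.min-1.g-1 on the same scale. Going by the values given here, these are the only two numbers so far and they lie within the scatter of each other, so compound 2 cannot be separated from compound 1 here.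

Compound 3 `CC(C)(N)CCOc1ccc([C@H]2CC[C@]3(CC2)OOC2(O3)C3CC4CC(C3)CC2C4)cc1` differs from compound 2 in one place: 1-amino-1-methylethyl in place of ((2-hydroxy-2-methylpropyl)amino)methyl on a saturated chain carbon, two bonds along the chain from an oxygen on an aromatic ring and, in words, 1-amino-1-methylethyl in place of ((2-hydroxy-2-methylpropyl)amino)methyl on a saturated chain carbon, two bonds along the chain from an oxygen on an aromatic ring. Cut one bond further out, this reads 3-((2-hydroxy-2-methylpropyl)amino)propoxy to 3-amino-3-methylbutoxy.

Among the compounds with values here, no measured pair makes this exact change. Within the data shown here, the one step that bears on it, though only loosely, is a 2.0-fold lower number from compound 1 to compound 2 (0.30 log units; within the scatter) and it replaces a whole group on an aromatic carbon. Because a 2.0-fold lower number from compound 1 to compound 2 (0.30 log units; within the scatter) stays within the scatter, no step beyond the scatter is expected here. The expected change is a 1.3-fold higher number from compound 2 to compound 3 (0.10 log units; within the scatter) and no clear direction is implied. For compound 3 the estimated value is 10 mL.min-1.g-1 with an expected range of 4 mL.min-1.g-1 to 25 mL.min-1.g-1 in this assay when it is measured.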

Compound 3, intrinsic clearance in microsomes: < 7 mL.min-1.g-1
Compound 3: only a limit was reported (the forecaster's own chance of this, stated with the estimate: 5%); middle value at least 1.4-fold (0.15 log units) away from the limit.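

In this assay compound 3 is reported only as a limit of the assay and not as a number: the limit of < 7 mL.min-1.g-1 in this assay, at which 1 of the 3 values shown sits.

On a saturated chain carbon, two bonds along the chain from an oxygen on an aromatic ring, 1-amino-1-methylethyl replaces ((2-hydroxy-2-methylpropyl)amino)methyl, and this gives an at least 1.1-fold lower number from compound 2 to compound 3 (0.05 log units; that floor lies within the scatter), so the change cannot yet be told apart from no change at all. The comparison with the sulfonyl side chain reads more clearly: putting 3-amino-3-methylbutoxy in place of (piperazin-1-yl)sulfonyl on an aromatic carbon gives an at least 2.2-fold lower number from compound 1 to compound 3 (0.35 log units; beyond the scatter), the first step among these compounds to pass beyond the scatter.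

Going by these compounds, the true number for compound 3 remains unknown, and with it the real size of both steps. Also open, on these data alone, is how this scale would read for a plain 3-aminopropoxy chain, which would test whether the two methyl groups on the chain matter, or for a carboxylic acid at the end of the same chain in place of the amine.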